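Ester-to-ketone switch at the carbonyl of compound 1

A few compounds are considered here, and "the series" means these few. Any claim that something is new, unique, unknown or untested is made for them only; others in the source may bear on it.

Compound 1 `CCCOC(=O)C1=C(C)NC(=O)NC1c1cccs1` stands highest of the two numbers in an assay on membranes from HeLa cells for displacement of a labelled ligand from adenosine receptor A3 (Homo sapiens), read by scintillation counting, with a stated time of 180 min, tested at 1 uM (on this read-out lower numbers stand for less inhibition and higher numbers for more inhibition at the one concentration tested (going by the name of the read-out)), where compound 1 gives 32%. Compound 2 `CCCOC(=O)C1=C(C)N(C)C(=O)NC1c1cccs1` gives 4% in this assay, a step of a number 28 percentage points lower from compound 1 to compound 2 (beyond the scatter) for methyl in place of hydrogen on an amide-type nitrogen in a ring. Compound 3 `CC1=C(C(=O)C2CC2)C(c2cccs2)NC(=O)N1` differs from compound 1 by cyclopropyl in place of propoxy on a carbonyl carbon. Among the measured compounds shown here, no measured step touches this carbonyl, so the only known step is uninformative here; a step no larger than the scatter is expected, a number 5 percentage points lower from compound 1 to compound 3 (within the scatter). Compound 3 is therefore estimated at 27%, between 5% and 50%.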

Compound 3, a percentage reported as inhibition, at one concentration (the size of the read-out at that concentration, not a potency): 15%
Estimate against measurement, compound 3: 12 percentage points above; the range from low to high includes it.
By their numbers in this assay, from the lowest: compound 2; then compound 3; then compound 1.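

The carbonyl position is not silent in this assay: cyclopropyl in place of propoxy on a carbonyl carbon gives a number 17 percentage points lower from compound 1 to compound 3 (beyond the scatter). Among the compounds shown here, this is the first measured change at this place, and it shows that propoxycarbonyl to cyclopropylcarbonyl costs inhibition on the core of compound 1. No available evidence accounts for the step.

With one ketone and one ester, the two changes in group type and in chain cannot be separated. On these data alone, whether a butoxy chain, a methyl ketone or an amine on this carbonyl carbon would match compound 1 remains open.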